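Turning One Double Bond From E to Z

The source may hold more compounds than are shown below. What is called first, only, known or untested is meant among the compounds shown, and "the series" means these compounds.

Compound 1 `CCCCCCCC/C=C\c1c(C)c(/C=C\CCCCCCCC)c2[n+](c1C)CCC2` gives 3.3 uM
Compound 2 `CCCCCCCC/C=C/c1c(C)cc(C)[n+]2c1CCC2` gives 1.3 uM

Both numbers come from a functional assay on M12 cells (Homo sapiens) for antiproliferative activity, read by WST assay, with a stated time of 72 h (on this read-out higher numbers stand for an effect only at larger amounts of compound and lower numbers for an effect already at smaller amounts), and compound 2 holds the lower one, with compound 1 above it by more than the usual scatter. Compound 3 `CCCCCCCC/C=C\c1c(C)cc(C)[n+]2c1CCC2` has not been measured yet. It is compound 2 with a single change (the two compounds have the same atoms and bonds and differ only in configuration as drawn: 1 of 1 stereo elements differ; a double bond is drawn E in compound 2 and Z in compound 3), so a double bond drawn E in compound 2 is drawn Z in compound 3. Among the compounds with values here, no measured pair shows this change alone. The only hint is weak, since compound 2 differs in more than one place from compound 1, whose double bonds are drawn Z and whose value is 3.3 uM in this comparison. A slightly higher number is expected, with the estimate being a 1.2-fold higher number from compound 2 to compound 3 (0.09 log units; within the scatter) and so no step beyond the scatter. For compound 3 the expected value is 1.6 uM within an estimated range of 0.7 uM to 3.6 uM in this assay once it is tested.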

Compound 3, concentration for half-maximal effect: 1.3 uM
The estimate for compound 3 lay 1.2-fold (0.09 log units) above the measured number; the measured number falls inside the stated range.
By their numbers in this assay, from the lowest: compounds 2 and 3 (each within the scatter of the next); then compound 1.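

In this assay, redrawing the double bond from E to Z gives no change at the digits printed from compound 2 to compound 3 (within the scatter), so at this position and on this chain, the configuration of the double bond does not separate the two compounds. Within the data shown here, this comparison isolates that single change, as nothing else distinguishes the pair: the fact that compounds 2 and 3 differ only in the configuration as drawn A second single change can now be read as well: hydrogen in place of dec-1-en-1-yl on an aromatic carbon gives a 2.5-fold lower number from compound 1 to compound 3 (0.40 log units; beyond the scatter), a modest step that no earlier pair could isolate.

Still open, as far as these compounds go, is whether the E and Z forms would stay level with a shorter or longer chain, or with a chain carrying an amine or a carboxylic acid. From the compounds shown here alone, these values also come from this assay alone, so whether the match holds in any other test remains unknown.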